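Swapping the Ring-Nitrogen Substituent: Estimating Compound 4

The source may hold more compounds than are shown below. What is called first, only, known or untested is meant among the compounds shown, and "the series" means these compounds.

Compound 1 `Fc1ccc(C(SCCNC2CCN(Cc3ccc(Cl)cc3)CC2)c2ccc(F)cc2)cc1` gives 45.5 nM in an assay on membranes from Cortex for displacement of a labelled ligand from Sigma non-opioid intracellular receptor 1 (Cavia porcellus), read by scintillation counting, with a stated time of 120 min; on this read-out higher numbers stand for weaker inhibition and lower numbers for stronger inhibition.
Compound 2 `Fc1ccc(C(SCCNC2CCN(Cc3ccc(C(F)(F)F)cc3)CC2)c2ccc(F)cc2)cc1` gives 186 nM in this assay.
Compound 3 `OC(Cc1ccccc1)CN1CCC(NCCSC(c2ccc(F)cc2)c2ccc(F)cc2)CC1` gives 309 nM in this assay.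

All three share the same core and differ only in the group carried by the amine nitrogen in the six-membered non-aromatic ring. Compound 3 has the highest number of the three: a 6.8-fold higher number from compound 1 to compound 3 (0.83 log units; beyond the scatter), whereas a 1.7-fold higher number from compound 2 to compound 3 (0.22 log units; within the scatter).

Compound 4 `O=C(c1cc2ccccc2o1)N1CCC(NCCSC(c2ccc(F)cc2)c2ccc(F)cc2)CC1` keeps that core and makes one change: (1-benzofuran-2-yl)carbonyl in place of 2-hydroxy-3-phenylpropyl on an amine nitrogen in a ring. Among the compounds with values here, no measured step exchanges an aryl-bearing chain for a carbonyl-linked group on this nitrogen, so there is no direct precedent. What the measured steps show is that changes at this position move the number by modest amounts only (a 6.8-fold higher number from compound 1 to compound 3 (0.83 log units; beyond the scatter); a 4.1-fold higher number from compound 1 to compound 2 (0.61 log units; beyond the scatter)). A step of similar or smaller size is therefore expected, with the direction uncertain and a slightly higher number judged somewhat more likely. Compound 4 is estimated at 400 nM, within 100 nM to 1600 nM, which would mean an expected 1.3-fold higher number from compound 3 to compound 4 (0.11 log units; within the scatter).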

Compound 4, inhibition constant: 304 nM
Estimate against measurement, compound 4: 1.3-fold (0.12 log units) above; measured number inside the range.
By their numbers in this assay, from the lowest: compound 1; then compounds 2, 4 and 3 (each within the scatter of the next).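

On the amine nitrogen in the ring, a carbonyl-linked group and a saturated chain are not told apart in this assay: replacing 2-hydroxy-3-phenylpropyl with (1-benzofuran-2-yl)carbonyl, which removes the hydrogen-bond donor and adds a five-membered aromatic ring, gives a 1.0-fold lower number from compound 3 to compound 4 (0.01 log units; within the scatter). Compound 4 also stands within the scatter of the 4-(trifluoromethyl)benzyl compound, with a 1.6-fold higher number from compound 2 to compound 4 (0.21 log units; within the scatter), while the 4-chlorobenzyl compound remains apart, with a 6.7-fold higher number from compound 1 to compound 4 (0.82 log units; beyond the scatter). No measurement shown here explains why these different groups give such similar numbers.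

Going by these compounds, it remains open whether the carbonyl link or the benzofuran ring matters more, which a (1-benzofuran-2-yl)methyl group on the same nitrogen could help separate. A 4-chlorobenzoyl group could likewise show whether the 4-chlorophenyl ring keeps its advantage when joined through a carbonyl.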